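This account rests on a few compounds, and the source may have more. Where it says the series, first, only, none or still open, it means among the compounds named here.

Values measured in an ADME assay on MRC5 cells (Homo sapiens) for cytotoxicity, read by neutral red uptake; on this read-out lower numbers stand for higher toxicity in this test and higher numbers for lower toxicity in this test:

- Compound 1 `O=c1[nH]c(SCc2cc([N+](=O)[O-])cc([N+](=O)[O-])c2)nc2ccc(Br)cc12` gives > 64000 nM, a limit of the assay and not a number.
- Compound 2 `Cc1ccc2nc(SCc3cc([N+](=O)[O-])cc([N+](=O)[O-])c3)[nH]c(=O)c2c1` gives > 64000 nM, also a limit of the assay.
- Compound 3 `CN(C)c1ccc2nc(SCc3cc([N+](=O)[O-])cc([N+](=O)[O-])c3)[nH]c(=O)c2c1` gives 14000 nM.

Compound 3 is the only one of the three with an actual number, 14000 nM. The other two stand at the limit of > 64000 nM in this assay, at which 2 of the 3 values shown sit. Compound 4 `CN1CCN(c2ccc3nc(SCc4cc([N+](=O)[O-])cc([N+](=O)[O-])c4)[nH]c(=O)c3c2)CC1` differs from compound 3 by one change, (4-methylpiperazin-1-yl in place of dimethylamino on an aromatic carbon), which puts 4-methylpiperazin-1-yl in place of dimethylamino on an aromatic carbon. Going by the values given here, the steps that bear on it are an at least 4.5-fold lower number from compound 1 to compound 3 (0.66 log units; beyond the scatter) and an at least 4.5-fold lower number from compound 2 to compound 3 (0.66 log units; beyond the scatter), both of which bring in the dimethylamino group at this carbon. They show that this place can move the number, yet neither replaces dimethylamino, and a step that the two limits leave unreadable from compound 1 to compound 2 gives no size at all. No step beyond the scatter is therefore expected in this assay, with only a slight lean towards a higher number. The expected change is a 1.3-fold higher number from compound 3 to compound 4 (0.11 log units; within the scatter). Compound 4 is estimated at 18000 nM, with an expected range from 6000 nM to 55000 nM.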

Compound 4, half-maximal cytotoxic concentration: 49000 nM
The estimate for compound 4 lay 2.7-fold (0.43 log units) below the measured number; low and high end bracket the measured number.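

In this assay, going by these compounds alone, this aromatic carbon had so far been seen only through steps that bring in dimethylamino, and exchanging that group now shows that the number also responds to which amine sits there: a 3.5-fold higher number from compound 3 to compound 4 (0.54 log units; beyond the scatter). Against the other two compounds, the readings are an at least 1.3-fold lower number from compound 2 to compound 4 (0.11 log units; that floor lies within the scatter) and an at least 1.3-fold lower number from compound 1 to compound 4 (0.11 log units; that floor lies within the scatter), floors that by themselves establish no real gap. Compound 1 and compound 2 each stand at a limit of the assay and not at a number: the limit of > 64000 nM in this assay, at which 2 of the 4 values shown sit.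

The compounds shown leave open whether the higher number goes with the six-membered ring itself or with its second nitrogen, a question on which a piperidine or morpholine ring at this carbon would bear. On these data alone, how a carboxylic acid at this place would read also remains open.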